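A few compounds are considered here, and "the series" means these few. Any claim that something is new, unique, unknown or untested is made for them only; others in the source may bear on it.

Compound 1, `S=c1n(-c2ccc(Cl)cc2)c(=S)n2n1CCCC2`, gives 89.1 nM in a functional assay on the whole organism for inhibition, with Echinochloa esculenta as the target; a higher number here means a weaker inhibitor, a lower number a stronger inhibitor. Compound 2, `S=c1n(-c2ccccc2)c(=S)n2n1CCCC2`, differs from it at one place: hydrogen in place of chloro on an aromatic carbon. That change produced a 40-fold higher number from compound 1 to compound 2 (1.60 log units; beyond the scatter), and in this assay compound 2 gives 3550 nM. Compound 3, `S=c1s/c(=N\c2ccc(Cl)cc2)n2n1CCCC2`, is built on a core that differs from that of compound 1; the difference between the two cores is not broken down here. In this assay compound 3 gives 407 nM, a higher number than compound 1 and a lower number than compound 2, so among the three measured compounds it stands second highest. Compound 4, `S=c1s/c(=N\c2ccccc2)n2n1CCCC2`, has not yet been measured. Within the data shown here, it differs from compound 3 by hydrogen in place of chloro on an aromatic carbon, the same change as the one that carried compound 1 to compound 2. Among the measured compounds shown here, on the basis of that single earlier step, the expected step is a 29-fold higher number from compound 3 to compound 4 (1.47 log units; beyond the scatter), though with only one precedent, on a different core, the expectation is loosely held. Compound 4 is accordingly expected to give about 12000 nM in this assay, most likely between 3000 nM and 50000 nM.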

Compound 4, half-maximal inhibitory concentration: 15100 nM
Beside the measured number, compound 4's estimate is 1.3-fold (0.10 log units) below it; the measured number falls inside the stated range.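

In this assay, hydrogen in place of chloro gave a 37-fold higher number from compound 3 to compound 4 (1.57 log units; beyond the scatter), and this step matches the earlier one on the other core: the same change on two cores in this assay, a 40-fold higher number (1.60 log units; beyond the scatter) from compound 1 to compound 2 and a 37-fold higher number (1.57 log units; beyond the scatter) from compound 3 to compound 4, 1.1-fold (0.03 log units) apart, within the scatter of two such steps. Between these two cores, then, the change carried over with its size intact, so the step read on the core of compound 1 held on the core of compound 3. This rests on one change and two cores, however, and it shows neither that the step would hold on any further core nor why the chloro group counts for so much in this series.

The compounds shown carry only chloro or hydrogen at this place on the aromatic ring, so they leave open whether a fluoro, bromo, methyl or methoxy group there would give a step of similar size. They also leave open how an amine or a longer chain attached elsewhere on either core would behave.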